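The source may hold more compounds than are shown below. What is called first, only, known or untested is meant among the compounds shown, and "the series" means these compounds.

Measured so far:
- compound 1, `Cc1c(NCc2nnc(-c3ccncc3)o2)c(=O)n(-c2ccccc2)n1C`, in a physicochemical assay for lipophilicity, measured as octanol-water partition (on this read-out lower numbers stand for lower lipophilicity and higher numbers for higher lipophilicity), compound 1 gives 0.8
- compound 2, `Cc1c(NCc2nnc(-c3ccccc3Cl)o2)c(=O)n(-c2ccccc2)n1C`, in this assay compound 2 gives 2.72

Compound 2 stands at the higher of the two numbers. Among the compounds with values here, its only neighbour is compound 1, and the step of a number 1.92 log units higher from compound 1 to compound 2 (beyond the scatter) is large, well beyond the usual scatter of the method; that step exchanged pyridin-4-yl for 2-chlorophenyl.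

Compound 3, `Cc1ccccc1-c1nnc(CNc2c(C)n(C)n(-c3ccccc3)c2=O)o1`, is not yet measured. It differs from compound 2 in one place: methyl in place of chloro on an aromatic carbon. Cut one bond further out, the same change reads 2-chlorophenyl to 2-methylphenyl.

Within the data shown here, no measured step exchanges chloro for methyl, so the one step on record does not bear directly on this change; it only shows how far this series can move in this assay when the whole aryl group is swapped. With a single heavy atom swapped for another single heavy atom, no ring, no donor or acceptor gained or lost, the step from compound 2 to compound 3 is expected to stay within the scatter, a number 0.12 log units lower from compound 2 to compound 3 (within the scatter). Compound 3 is therefore estimated at 2.6, with a range from 2.2 to 3.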

Compound 3, partition coefficient: 2.38
Estimate against measurement, compound 3: 0.22 log units above; low and high end bracket the measured number.
By their numbers in this assay, from the lowest: compound 1; then compound 3; then compound 2.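

In this assay, even a swap of one heavy atom at this place registers: a number 0.34 log units lower from compound 2 to compound 3 (beyond the scatter), a modest step but one that the method can resolve, although neither chloro nor methyl brings a ring, a hydrogen-bond donor or acceptor, or a charge. The new compound also gives a second measure of the effect of replacing pyridin-4-yl: a number 1.58 log units higher from compound 1 to compound 3 (beyond the scatter), so a large step appears with 2-methylphenyl as well as with 2-chlorophenyl, and the choice between chloro and methyl on the phenyl ring moves the number far less than the step away from pyridin-4-yl. Nothing available here accounts for the difference between chloro and methyl, so the numbers describe it without explaining it.

As far as these compounds go, it remains open where other groups on this aromatic carbon, such as a methoxy group, a fluorine atom, an amine or a carboxylic acid, would fall relative to compound 2 and compound 3. From the compounds shown here alone, it is also open whether chloro and methyl would stand in the same order, and by a similar amount, at another carbon of the phenyl ring or on a different core.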